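The source may report more compounds than this note shows. Statements on the series, on what has been measured and on what is new or still open speak of the compounds shown alone.

Among the compounds with values here, compound 2 `CC(C)CC(=O)Nc1ccn([C@H]2CC[C@H](O[C@H]3O[C@H](C)[C@@H](N(C)C)[C@H](O)[C@H]3O)[C@@H](C)O2)c(=O)n1` stands at the high end of the two numbers measured so far: in a functional assay on HCT-116 cells (Homo sapiens) for cytotoxicity, read by sulforhodamine B assay, with a stated time of 24 h (a higher number here means a weaker inhibitor, a lower number a stronger inhibitor), compound 2 gives 2140 nM, while compound 1 `CC(C)CCC(=O)Nc1ccn([C@H]2CC[C@H](O[C@H]3O[C@H](C)[C@@H](N(C)C)[C@H](O)[C@H]3O)[C@@H](C)O2)c(=O)n1` gives 390 nM. Within the data shown here, the one step that joins them, a 5.5-fold higher number from compound 1 to compound 2 (0.74 log units; beyond the scatter), is the only comparison available, and it shows that taking a single carbon out of the chain on the carbonyl carbon costs a modest but real amount of potency.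

Compound 3 `CC(C)/C=C/C(=O)Nc1ccn([C@H]2CC[C@H](O[C@H]3O[C@H](C)[C@@H](N(C)C)[C@H](O)[C@H]3O)[C@@H](C)O2)c(=O)n1` differs from compound 2 by 3-methylbut-1-en-1-yl in place of isobutyl on a carbonyl carbon. Among the measured compounds shown here, this change restores a carbon to the chain and, in addition, introduces a double bond outside aromatic rings; the result is a chain of the same length as the one in compound 1, but unsaturated. The step from compound 1 to compound 2 bears on this directly, and in reverse: lengthening the chain again should lower the number. Compound 3 is therefore expected to move back toward compound 1, with an estimated step of a 4.3-fold lower number from compound 2 to compound 3 (0.63 log units; beyond the scatter) in this assay. The estimate for compound 3 is 500 nM, within a range from 200 nM to 1500 nM.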

Compound 3, half-maximal inhibitory concentration: 780 nM
For compound 3 the middle estimate is 1.6-fold (0.19 log units) below the measured one; the range from low to high includes it.
By their numbers in this assay, from the lowest: compounds 1 and 3 (each within the scatter of the next); then compound 2.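

Replacing isobutyl on this carbonyl carbon with 3-methylbut-1-en-1-yl gives a 2.7-fold lower number from compound 2 to compound 3 (0.44 log units; beyond the scatter) in this assay and so shows that the higher number of compound 2 is not tied to the saturated isopentyl chain alone: an unsaturated chain at this place also gives a lower number than isobutyl does. The comparison of the two longer chains is a 2.0-fold higher number from compound 1 to compound 3 (0.30 log units; within the scatter) and so the double bond outside aromatic rings makes no difference that can be read in this pair, which leaves the isobutyl chain of compound 2 as the one that stands apart among the three compounds. Nothing measured on these compounds explains why the isobutyl chain stands apart in this way.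

The compounds shown leave open how a longer chain, a cyclohexyl ring or a phenyl ring on this carbonyl carbon would read in this assay and whether the number would keep falling as the chain grows. They also leave open whether the cis form of the double bond would read like the trans form of compound 3, and whether the same order of the three chains would hold in any other cell line.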